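The compounds below may be only part of what the source reports. "The series", "measured", "known", "first", "only" and "open" are said of these compounds alone.

In an ADME assay on HEp-2 cells (Homo sapiens) for cytotoxicity (a lower number here means that less compound is tolerated, a higher number that more compound is tolerated), compound 1 `CC(C)CCn1c(Cn2c(=O)n(C(C)C)c3ccccc32)nc2cc(CN(C)C)ccc21` gives 5650 nM. Compound 2 `C=C(C)n1c(=O)n(Cc2nc3cc(C(=N)N)ccc3n2CCC(C)C)c2ccccc21` gives 10800 nM, and compound 3 `CC(C)CCn1c(Cn2c(=O)n(CC(=O)OC(C)(C)C)c3ccccc32)nc2cc(C(=N)N)ccc21` gives 7900 nM. Compound 1 therefore stands within the scatter of both other compounds, and no order can be drawn among the three.

Compound 4 `CC(C)CCn1c(Cn2c(=O)n(C(C)C)c3ccccc32)nc2cc(CO)ccc21` has not yet been measured in this assay. It keeps the core and side chains of compound 1, with one change: hydroxy in place of dimethylamino on a saturated chain carbon bound to an aromatic carbon, or (dimethylamino)methyl to hydroxymethyl when cut one bond further out. hydroxy in place of dimethylamino on a saturated chain carbon bound to an aromatic carbon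

Among the measured compounds shown here, no measured step tests this change directly. The only one available is a 1.4-fold lower number from compound 2 to compound 3 (0.14 log units; within the scatter), and it concerns a group on an aromatic nitrogen, not the site altered here. It therefore bears on the present question only indirectly, showing that a large exchange elsewhere on the molecule left the number within the scatter. With nothing measured at the altered site, no step beyond the scatter is expected, although the uncertainty is wide and leans upward. The expected change is a 1.6-fold higher number from compound 1 to compound 4 (0.20 log units; within the scatter), an estimate that remains within the scatter. For compound 4, the estimated value is 9000 nM, with an expected range of 4000 nM to 30000 nM.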

Compound 4, half-maximal cytotoxic concentration: 31600 nM
The estimate for compound 4 lay 3.5-fold (0.55 log units) below the measured number, outside the stated range (above it).
By their numbers in this assay, from the lowest: compounds 1, 3 and 2 (each within the scatter of the next); then compound 4.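

In this assay, exchanging dimethylamino for hydroxy on a saturated chain carbon bound to an aromatic carbon gives a 5.6-fold higher number from compound 1 to compound 4 (0.75 log units; beyond the scatter), and this is the only step among the compounds shown that lies beyond the scatter. Among the compounds shown here, the one earlier step, a 1.4-fold lower number from compound 2 to compound 3 (0.14 log units; within the scatter), concerned a group on an aromatic nitrogen and stayed within the scatter, so this chain position is the first place where a single exchange is seen to move the number, with more compound tolerated after the change from (dimethylamino)methyl to hydroxymethyl. No measurement available here accounts for the size or direction of this step.

One pair cannot separate what the departure of dimethylamino contributes from what the arrival of hydroxy contributes, and a primary amine, a methoxy group or a carboxylic acid on the same carbon would be needed to tell these apart. Going by these compounds, it also remains open whether the exchange would give a step of similar size with a different group on the aromatic nitrogen of the shared core.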